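A few compounds are considered here, and "the series" means these few. Any claim that something is new, unique, unknown or untested is made for them only; others in the source may bear on it.

Going by the values given here, in a functional assay on SW480 cells (Homo sapiens) for cytotoxicity, read by sulforhodamine B assay, with a stated time of 48 h (a lower number here means a stronger inhibitor, a higher number a weaker inhibitor), compound 1 (`O=C(/C=C/c1ccc(Br)cc1)c1cccc(-c2cccc(F)c2)c1`) gives 18200 nM as the only number available so far. Alongside it stands compound 2 (`COc1ccc(/C=C/C(=O)c2cccc(-c3cccc(F)c3)c2)cc1O`), and for compound 2 the entry reads "not determined" (no result reported) with no result behind it, so no measured step exists. Compound 3 (`O=C(/C=C/c1cccc(Br)c1)c1cccc(-c2cccc(F)c2)c1`) has the same atoms as compound 1, joined differently: 3-bromophenyl in place of 4-bromophenyl on a double-bonded chain carbon bound to a double-bonded chain carbon describes the change, 3-bromophenyl in place of 4-bromophenyl on a double-bonded chain carbon bound to a double-bonded chain carbon. With nothing else to compare, the expectation rests on compound 1 at 18200 nM alone and foresees no step beyond the scatter in this assay in either direction. The estimated change is a 1.0-fold lower number from compound 1 to compound 3 (0.00 log units; within the scatter) and no more. For compound 3 the expected value is 18000 nM with a range of 8000 nM to 40000 nM in this estimate.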

Compound 3, half-maximal inhibitory concentration: 8610 nM
Estimate against measurement, compound 3: 2.1-fold (0.32 log units) above, and the stated range covers the measured number.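

In this assay, 3-bromophenyl in place of 4-bromophenyl on a double-bonded chain carbon bound to a double-bonded chain carbon gives a 2.1-fold lower number from compound 1 to compound 3 (0.33 log units; beyond the scatter). Going by these compounds alone, this modest step is the first measured change, and it shows that the number at this place can move beyond the scatter even when the two compounds have the same atoms, joined differently. Nothing further is available to explain the step.

Going by these compounds, with one pair, it remains open whether this step is specific to bromine or would recur with another group, such as 3-chlorophenyl or 3-aminophenyl, at the same place. It is also unknown whether a carboxylic acid or an amine on this ring would move the number further than compound 3 does.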